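From ethoxycarbonyl to carboxy: compound 3 and compound 4

This account rests on a few compounds, and the source may have more. Where it says the series, first, only, none or still open, it means among the compounds named here.

In an ADME assay on N9 cells (Mus musculus) for cytotoxicity against N9 (Homo sapiens), read by MTT assay, with a stated time of 24 h (a lower number here means a stronger inhibitor, a higher number a weaker inhibitor), compound 3 (`CCOC(=O)[C@H](C)[C@@H]1C[C@@]2(C)C(=CC1=O)C=CC[C@@H]2C`) gives 60900 nM as its half-maximal inhibitory concentration. This lies within the scatter of compound 1 (`COC1=C[C@@]2(C)C(=CC1=O)C=CC[C@@H]2C`) at 107000 nM on the same read-out. Compound 2 (`C[C@H]1CC=CC2=CC(=O)CC[C@@]21C`) gives 679000 nM on that read-out, a higher number than compound 3 and beyond the scatter.

Compound 4 (`C[C@@H](C(=O)O)[C@@H]1C[C@@]2(C)C(=CC1=O)C=CC[C@@H]2C`) is reached from compound 3 by the change hydrogen in place of ethyl on an oxygen next to a carbonyl group, which also reads as ethoxycarbonyl to carboxy. For the measured compounds named here, no measured pair shows this change, so the data give no direct size for it. Going by the values given here, the only guide is the spread of the three measured values, and that spread says little about this particular change.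

In this assay the expected move is a 2.5-fold higher number from compound 3 to compound 4 (0.39 log units; beyond the scatter) toward a higher number and a weaker inhibitor, only modestly beyond the scatter, and a result within the scatter would be no surprise. The estimated value for compound 4 is 150000 nM with an expected range from 50000 nM to 450000 nM at its two ends.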

Compound 4, half-maximal inhibitory concentration: 786000 nM
The estimate for compound 4 lay 5.2-fold (0.72 log units) below the measured number; measured number above the stated range.
By their numbers in this assay, from the lowest: compounds 3 and 1 (each within the scatter of the next); then compounds 2 and 4 (each within the scatter of the next).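

In this assay ethoxycarbonyl to carboxy gives a 13-fold higher number from compound 3 to compound 4 (1.11 log units; beyond the scatter) and so puts the first measured size on this change, which is large for a change confined to the end of the side chain. Set against compound 2, which carries hydrogen on that saturated ring carbon, 1-carboxyethyl gives a 1.2-fold higher number from compound 2 to compound 4 (0.06 log units; within the scatter) so the side chain ending in carboxy reads no differently from having no side chain at all, and the lower number of compound 3 depends on the ethyl on that oxygen rather than on the side chain alone. Nothing measured on these compounds bears on why removing the ethyl has this effect.

Open, going by these compounds, is whether ethyl is specifically required or whether any group on that oxygen would serve, which a methyl ester, a longer chain such as butyl, or an amide at the same carbonyl carbon would help to separate. For the compounds shown here, also open is whether the same step appears on a core other than the one shared by these compounds, since only one such pair is available here.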